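The source may hold more compounds than are shown below. What is called first, only, known or untested is meant among the compounds shown, and "the series" means these compounds.

The measured compounds:
Compound 1, `CN(c1ccc(OCCCC(=O)NO)cc1)c1ncnc2ccccc12`, gives 34 nM.
Compound 2, `Cc1nc2c(c(N(C)c3ccc(OCCCC(=O)NO)cc3)n1)CCC2`, gives 40 nM.

Both numbers come from an assay on isolated protein for inhibition of protein deacetylase HDAC6 (Homo sapiens), read by fluorescence, with a stated time of 1 h; on this read-out higher numbers stand for weaker inhibition and lower numbers for stronger inhibition. Compound 2 and compound 1 lie within the usual scatter of each other, so nothing on this evidence separates them, and neither can be called the stronger inhibitor. Compound 3, `Cc1nc2c(c(N(C)c3ccc(OCCCCCC(=O)NO)cc3)n1)CCC2`, has not yet been measured. It keeps the core of compound 2 and alters only the chain: 2-(hydroxycarbamoyl)ethyl in place of hydroxycarbamoyl on a saturated chain carbon, three bonds along the chain from an oxygen on an aromatic ring. The chain between the aromatic oxygen and the hydroxycarbamoyl end thus grows longer. Within the data shown here, no measured pair here shows what such a lengthening does, so the expectation rests on the two measured compounds and the change alone. The expected step is a 1.5-fold higher number from compound 2 to compound 3 (0.18 log units; within the scatter) in this assay, a shift of modest size at most, toward weaker inhibition if any. Compound 3 is therefore estimated at 60 nM in this assay, within a range from 15 nM to 250 nM.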

Compound 3, half-maximal inhibitory concentration: 20 nM
Compound 3: the middle estimate sits 3.0-fold (0.48 log units) above what was measured, within the range that was stated.
By their numbers in this assay, from the lowest: compounds 3, 1 and 2 (each within the scatter of the next).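

In this assay, putting 2-(hydroxycarbamoyl)ethyl in place of hydroxycarbamoyl on a saturated chain carbon, three bonds along the chain from an oxygen on an aromatic ring, gives a 2.0-fold lower number from compound 2 to compound 3 (0.30 log units; within the scatter) for this lengthening. Among these compounds, this is the first measured change at this position, and it shows that the longer chain keeps inhibition of the enzyme, while compound 2 and compound 3 cannot be told apart on these numbers. Nothing available gives a measured reason for this result.

Still open, going by these compounds, is how a longer chain would read at this position, or a carboxylic acid at the chain end in place of the hydroxycarbamoyl group. Also open, on these data alone, is whether the same lengthening on the core of compound 1 would give a similar result.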